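Swapping the Amine Group on the Shared Core

A few compounds are considered here, and "the series" means these few. Any claim that something is new, unique, unknown or untested is made for them only; others in the source may bear on it.

In an assay on VSM-A10 cells for antagonist activity at Endothelin-1 receptor (Rattus norvegicus) (on this read-out higher numbers stand for weaker inhibition and lower numbers for stronger inhibition), compound 2 `Cc1noc(NS(=O)(=O)c2cccc3c(CN(C)C)cccc23)c1C` gives 2800 nM, and compound 1 `Cc1noc(NS(=O)(=O)c2cccc3c(NCCCCCc4ccccc4)cccc23)c1C` gives 3050 nM; the two numbers lie within the scatter of each other, so compound 2 stands alongside compound 1 rather than apart from it. Compound 3 `Cc1noc(NS(=O)(=O)c2cccc3c(NC(C)C)cccc23)c1C` differs from compound 2 by isopropylamino in place of (dimethylamino)methyl on an aromatic carbon. For the measured compounds named here, no step between measured compounds is available. Because compound 1 also carries an amino group on the core and gives 3050 nM, the step of a 1.1-fold lower number from compound 2 to compound 3 (0.05 log units; within the scatter) is expected to stay within the scatter. Compound 3 is therefore estimated at 2500 nM, with a range from 800 nM to 8000 nM.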

Compound 3, half-maximal inhibitory concentration: 20 nM
Estimate against measurement, compound 3: 130-fold (2.10 log units) above; the whole stated range lies above it.
By their numbers in this assay, from the lowest: compound 3; then compounds 2 and 1 (each within the scatter of the next).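

In this assay, this aromatic carbon proves far from indifferent to its group: isopropylamino in place of (dimethylamino)methyl gives a 140-fold lower number from compound 2 to compound 3 (2.15 log units; beyond the scatter), though both groups have the same heavy-atom count. On the nitrogen on the aromatic ring, isopropyl in place of 5-phenylpentyl gives a 150-fold lower number from compound 1 to compound 3 (2.18 log units; beyond the scatter), so an amino group on the core does not by itself set the number. From the compounds shown here alone, whether an ethyl group or a cyclohexyl ring on that nitrogen would match isopropyl stays open, as does the outcome with a dimethylamino group directly on the aromatic carbon. No measurement at hand gives a cause for these steps.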